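Dropping the halogen from the core: solubility of compound 3

This account rests on a few compounds, and the source may have more. Where it says the series, first, only, none or still open, it means among the compounds named here.

Compound 1, `CC(C)n1nc(-c2ccc3oc(N)nc3c2)c2c(Cl)nc(N)nc21`: 2000 nM
Compound 2, `CC(C)n1nc(-c2ccc3oc(N)nc3c2)c2c(F)nc(N)nc21`: < 1000 nM

For the measured compounds named here, in a physicochemical assay for solubility, read by HPLC, in phosphate buffer, measured as kinetic solubility, with a stated time of 24 h, at 20 degrees C, at pH 7.4, tested at 100 uM (on this read-out higher numbers stand for higher solubility and lower numbers for lower solubility), compound 1 gives 2000 nM, the only number among the two values shown. Compound 2 reaches only a limit of this assay, < 1000 nM, and that limit is the point marked by the limit of < 1000 nM in this assay, at which 1 of the 2 values shown sits. From the compounds shown here alone, the measured step of an at least 2.0-fold lower number from compound 1 to compound 2 (0.30 log units; that floor lies within the scatter) therefore shows a drop whose floor lies within the scatter, so its true size stays open. Compound 3, `CC(C)n1nc(-c2ccc3oc(N)nc3c2)c2cnc(N)nc21`, differs from compound 1 by hydrogen in place of chloro on an aromatic carbon. Going by the values given here, no measured step removes a halogen outright; the single step from compound 1 to compound 2 only exchanges one halogen for another, so it bears on this change only loosely. On that thin basis compound 3 is expected to land near compound 1 in this assay, with no change at the digits printed from compound 1 to compound 3 (within the scatter) as the expected step. The estimate for compound 3 is 2000 nM, within a range from 800 nM to 5000 nM.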

Compound 3, solubility: 1600 nM
Beside the measured number, compound 3's estimate is 1.3-fold (0.10 log units) above it; low and high end bracket the measured number.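

For the compounds shown here, with hydrogen in place of chloro on this aromatic carbon, this assay gives a 1.3-fold lower number from compound 1 to compound 3 (0.10 log units; within the scatter), the first reading of a core with no halogen at this position, and it cannot be told apart from the chloro compound. Hydrogen in place of fluoro gives an at least 1.6-fold higher number from compound 2 to compound 3 (0.20 log units; that floor lies within the scatter), which is only a floor, so the true size of this step stays open. Compound 2 remains the one compound that reaches only a limit of this assay: the limit of < 1000 nM in this assay, at which 1 of the 3 values shown sits.

How far compound 2 truly lies from compound 1 and compound 3 stays unresolved. How an amine, a methoxy group or a longer chain on this aromatic carbon would read in this assay also remains open, as the compounds shown carry only chloro, fluoro or hydrogen here.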